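The source may report more compounds than this note shows. Statements on the series, on what has been measured and on what is new or still open speak of the compounds shown alone.

Compound 1 `N[C@]1(C(=O)O)[C@H]2[C@@H](C[C@H]1OCc1ccc(-c3ccccc3)cc1)[C@]2(F)C(=O)O`: 25.6 nM
Compound 2 `N[C@]1(C(=O)O)[C@H]2[C@@H](C[C@H]1OCc1cccc([N+](=O)[O-])c1)[C@]2(F)C(=O)O`: 7.87 nM
Compound 3 `Nc1cccc(CO[C@@H]2C[C@@H]3[C@H]([C@]2(N)C(=O)O)[C@@]3(F)C(=O)O)c1`: 15.4 nM

All three share one core and differ only in the group carried on the benzyl ether. In an assay on CHO cells for binding affinity to metabotropic glutamate receptor 2 (Rattus norvegicus) (on this read-out lower numbers stand for stronger inhibition and higher numbers for weaker inhibition), compound 1 gives 25.6 nM, compound 2 gives 7.87 nM, and compound 3 gives 15.4 nM. Compound 3 stands second highest of the three numbers, but its gap to compound 1 and its gap to compound 2 both lie within the usual scatter, so no ranking among them can be read. Going by the values given here, the only single change measured, a 2.0-fold higher number from compound 2 to compound 3 (0.29 log units; within the scatter), also stays within the scatter.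

Compound 4 `N[C@]1(C(=O)O)[C@H]2[C@@H](C[C@H]1OCc1ccc(F)c(Cl)c1)[C@]2(F)C(=O)O` differs from compound 3 in one place: 3-chloro-4-fluorophenyl in place of 3-aminophenyl on a saturated chain carbon bound to an oxygen on a saturated carbon. Among the compounds with values here, no measured step swaps an amino for a halogen, so none bears directly on this change; what the three measured compounds show is that varied groups on that ring all fall within a narrow band. Compound 4 is therefore expected to fall in the same band, with a number estimated at 8 nM and a range from 3 nM to 25 nM. This estimate means a 1.9-fold lower number from compound 3 to compound 4 (0.28 log units; within the scatter) is expected, a step not beyond the scatter.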

Compound 4, inhibition constant: 3.57 nM
The estimate for compound 4 lay 2.2-fold (0.35 log units) above the measured number; the range from low to high includes it.
By their numbers in this assay, from the lowest: compound 4; then compounds 2, 3 and 1 (each within the scatter of the next, the first and the last beyond it).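

In this assay, a 4.3-fold lower number from compound 3 to compound 4 (0.63 log units; beyond the scatter) is the first step among these compounds that lies beyond the scatter, although it is modest in size. Going by these compounds alone, it shows that the group on this saturated chain carbon can shift the number by a readable amount, which the earlier compounds could not show, while compound 4 and compound 2 still lie within the scatter of each other. No measured evidence here explains the step.

The change removes an amino group and brings in both a chlorine and a fluorine, so the compounds shown do not tell whether one halogen alone would give the same step. Also open, on these data alone, is what a carboxylic acid or a methoxy group on the same ring would do to the number.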